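Series notes: chain substituent variation on the shared core

The source may hold more compounds than are shown below. What is called first, only, known or untested is meant among the compounds shown, and "the series" means these compounds.

Compound 1 `CCN(CC)C(=O)Cn1c(=N)sc2cc(OC(F)(F)F)ccc21` and compound 2 `CNS(=O)(=O)CCn1c(=N)sc2cc(OC(F)(F)F)ccc21` share one core and differ only in the group on a saturated chain carbon bound to an aromatic nitrogen. In a functional assay on the whole organism with Rattus norvegicus as the target (on this read-out higher numbers stand for an effect only at larger amounts of compound and lower numbers for an effect already at smaller amounts), compound 1 gives 9 mg/kg, while compound 2 gives 4 mg/kg, the measured step being a 2.3-fold lower number from compound 1 to compound 2 (0.35 log units; beyond the scatter). Among the compounds with values here, compound 2 thus holds the lowest of the two numbers so far, with compound 1 the nearest at a higher number.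

Compound 3 `N=c1sc2cc(OC(F)(F)F)ccc2n1CC[S+]([O-])c1ccccc1` is not yet measured. It differs from compound 2 as follows: a group of 8 heavy atoms (6 carbon, 1 oxygen, 1 sulfur; one six-membered aromatic ring of carbon only) in place of a group of 5 heavy atoms (1 carbon, 1 nitrogen, 2 oxygen, 1 sulfur; no ring), on a saturated chain carbon, two bonds along the chain from an aromatic nitrogen. Within the data shown here, the only measured step, a 2.3-fold lower number from compound 1 to compound 2 (0.35 log units; beyond the scatter), concerns the substituent on the chain carbon bound to the aromatic nitrogen rather than a group two bonds along, so it bears on the new change only as a sign that exchanges on this chain have moved this assay modestly. Among the measured compounds shown here, no measured pair shows what the entering group does. The estimate for compound 3 means a step of a 1.3-fold higher number from compound 2 to compound 3 (0.10 log units; within the scatter), expected to lie about at the edge of the scatter. For compound 3 the expected value in this assay is 5 mg/kg, with a range from 2 mg/kg to 12 mg/kg.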

Compound 3, dose for half-maximal effect: 4.2 mg/kg
Compound 3: the middle estimate sits 1.2-fold (0.08 log units) above what was measured, within the range that was stated.
By their numbers in this assay, from the lowest: compounds 2 and 3 (each within the scatter of the next); then compound 1.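

Series notes: reading of the new step

At the saturated chain carbon, two bonds along the chain from an aromatic nitrogen, the group with one six-membered aromatic ring of carbon only replaces methylsulfamoyl, and this assay gives a 1.1-fold higher number from compound 2 to compound 3 (0.02 log units; within the scatter), so this read-out does not separate compound 2 from compound 3. The earlier pair concerned a different exchange on the chain; this step shows that, at this place, a group with a carbon-only aromatic ring, 0 hydrogen-bond donors and 1 hydrogen-bond acceptor can stand in for methylsulfamoyl, with its 1 hydrogen-bond donor and 2 hydrogen-bond acceptors, without a step beyond the scatter. No measurement on these compounds speaks to what lies behind this result.

The compounds shown do not separate the part played by the aromatic ring from that of the sulfur-bearing link, as the exchange replaces the whole group at once. Also open, from the compounds shown here alone, is how this read-out responds at the same place to an amine, a carboxylic acid or a longer chain carrying the same phenyl ring.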